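The source may report more compounds than this note shows. Statements on the series, on what has been measured and on what is new or still open speak of the compounds shown alone.

In a functional assay on MCF7 cells (Homo sapiens) for inhibition, read by MTT assay, with a stated time of 72 h (on this read-out higher numbers stand for weaker inhibition and lower numbers for stronger inhibition), compound 2 `O=c1ccn(COC(CO)CO)c(=O)[nH]1` gives only a limit, > 100000 nM. Compound 1 `Cc1cc(=O)[nH]c(=O)n1COC(CO)CO` likewise gives a limit, > 100000 nM. Compound 3 `CC(C)(C)OC(=O)NCCNCC(=O)Nc1c[nH]c(=O)[nH]c1=O` also gives a limit, > 100000 nM. The step from compound 1 to compound 2 is a step that the two limits leave unreadable from compound 1 to compound 2, so its size cannot be told. Every value here rests at the limit of > 100000 nM in this assay, at which 3 of the 3 values shown sit. Compound 4 `O=c1[nH]c(=O)n(COC(CO)CO)cc1O` differs from compound 2 by hydroxy in place of hydrogen on an aromatic carbon. Among the compounds with values here, no measured step bears directly on this change, and the one step between measured compounds is not readable, so compound 2 supplies no number from which a shift could be reckoned. Compound 4 is therefore expected to stay near the same limit, with an estimated step that the limit leaves unreadable from compound 2 to compound 4. The estimated value for compound 4 is 150000 nM, with a range from 40000 nM to 500000 nM.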

Compound 4, half-maximal inhibitory concentration: > 100000 nM
Compound 4 gave a limit, no number; the forecaster's own chance of this, stated with the estimate: 80%; the middle value is on the limit's open side.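

Compound 4 gives only a limit, > 100000 nM, and compound 2 also gives only a limit, so no step can be read between them. The compounds shown leave open whether any of these changes shifts the read-out at all, as every value rests at one place: the limit of > 100000 nM in this assay, at which 4 of the 4 values shown sit.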